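The source may hold more compounds than are shown below. What is called first, only, known or untested is meant among the compounds shown, and "the series" means these compounds.

Working notes on the quinolinylmethoxy-phenyl series. In an assay on membranes from lung (Cavia porcellus) for binding affinity to cysteinyl leukotriene receptor (Homo sapiens) (a higher number here means a weaker inhibitor, a lower number a stronger inhibitor), compound 1 `O=C(O)CC1CCC(c2ccc(OCc3ccc4ccccc4n3)cc2)C1` gives 22 nM, compound 2 `O=C(O)CCC(Cc1cccc(OCc2ccc3ccccc3n2)c1)c1ccccc1` gives 52 nM and compound 3 `c1ccc(C(CCc2nnn[nH]2)Cc2cccc(OCc3ccc4ccccc4n3)c2)cc1` gives 14 nM. For the measured compounds named here, compound 2 therefore holds the highest number of the three, beyond the scatter from both compound 1 and compound 3; the one single-point step measured so far, a 3.7-fold lower number from compound 2 to compound 3 (0.57 log units; beyond the scatter), concerns the acid head rather than the chain substituent.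

Compound 4 `CCCC(CCC(=O)O)Cc1cccc(OCc2ccc3ccccc3n2)c1` differs from compound 2 in one place: propyl in place of phenyl on a saturated chain carbon bound to two saturated chain carbons. Going by the values given here, no measured pair in the set changes this position, so the step from compound 2 to compound 3 does not bear on it and there is nothing to extrapolate from. Compound 1, with its different chain arrangement, shows only that the series tolerates variation near the acid, not what propyl does at this carbon. Among the compounds with values here, with no guiding step, the expectation for this assay is a number close to that of compound 2, possibly somewhat higher, with wide uncertainty. Compound 4 is estimated at 80 nM, within 25 nM to 250 nM, meaning an expected step of a 1.5-fold higher number from compound 2 to compound 4 (0.19 log units; within the scatter).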

Compound 4, inhibition constant: 50 nM
Estimate against measurement, compound 4: 1.6-fold (0.20 log units) above; the range from low to high includes it.
By their numbers in this assay, from the lowest: compounds 3 and 1 (each within the scatter of the next); then compounds 4 and 2 (each within the scatter of the next).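

In this assay the first measured replacement at this saturated chain carbon bound to two saturated chain carbons gives a 1.0-fold lower number from compound 2 to compound 4 (0.02 log units; within the scatter) and so leaves compound 2 and compound 4 indistinguishable. In this pair, the six-membered aromatic ring of phenyl is therefore not needed for a value in this range, since propyl, with no ring and fewer heavy atoms, serves equally well here. No measured property is available to explain this equivalence.

On these data alone, what a longer chain such as hexyl, or an amine or a hydroxyl, would do at this carbon remains open. Also open, as far as these compounds go, is whether 1H-tetrazol-5-yl in place of carboxy would act on the propyl compound as it does in a 3.7-fold lower number from compound 2 to compound 3 (0.57 log units; beyond the scatter) on the phenyl one.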